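Replacing One Aromatic Ring on the Carbonyl Carbon

The source may report more compounds than this note shows. Statements on the series, on what has been measured and on what is new or still open speak of the compounds shown alone.

Three measured compounds share one core and differ only in the aromatic ring attached to the carbonyl carbon. Compound 1 `COc1ccc(/C=C/c2cc(OC)cc(OC)c2/C=C/C(=O)c2ccc(N)cc2)cc1` gives 7.5 ug/mL in a functional assay on HepG2 cells (Homo sapiens) for antiproliferative activity, read by MTT assay, with a stated time of 48 h; a lower number here means a stronger inhibitor, a higher number a weaker inhibitor. Compound 2 `COc1ccc(/C=C/c2cc(OC)cc(OC)c2/C=C/C(=O)c2ccc(C(F)(F)F)cc2)cc1` gives 18.7 ug/mL in this assay, and compound 3 `COc1ccc(/C=C/c2cc(OC)cc(OC)c2/C=C/C(=O)c2cccc(OC)c2)cc1` gives 11.6 ug/mL. On the numbers shown, compound 3 stands second highest of the three, but its gaps to both others are small: a 1.5-fold higher number from compound 1 to compound 3 (0.19 log units; within the scatter) and a 1.6-fold lower number from compound 2 to compound 3 (0.21 log units; within the scatter). For the measured compounds named here, the only step beyond the scatter is a 2.5-fold higher number from compound 1 to compound 2 (0.40 log units; beyond the scatter).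

Going by the values given here, compound 4 `COc1ccc(/C=C/c2cc(OC)cc(OC)c2/C=C/C(=O)c2ccc(-c3ccccc3)cc2)cc1` is the next step from compound 3. 4-phenylphenyl in place of 3-methoxyphenyl on a carbonyl carbon No measured step introduces 4-phenylphenyl, so the two steps that exchanged rings on the carbonyl carbon are the nearest guide, and both stayed within the scatter, while the whole set covers only a modest span. A step of similar size is expected, so a 1.2-fold higher number from compound 3 to compound 4 (0.08 log units; within the scatter) is the expected change, with no clear direction. Compound 4 is therefore estimated at 14 ug/mL, within a range from 6 ug/mL to 35 ug/mL.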

Compound 4, half-maximal inhibitory concentration: 10.5 ug/mL
For compound 4 the middle estimate is 1.3-fold (0.12 log units) above the measured one, and the stated range covers the measured number.
By their numbers in this assay, from the lowest: compounds 1, 4, 3 and 2 (each within the scatter of the next, the first and the last beyond it).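

Although 4-phenylphenyl has more heavy atoms than 3-methoxyphenyl, two aromatic rings rather than one, and no hydrogen-bond acceptor, the exchange on the carbonyl carbon changes little in this assay (a 1.1-fold lower number from compound 3 to compound 4 (0.04 log units; within the scatter)). With phenyl in place of trifluoromethyl (a 1.8-fold lower number from compound 2 to compound 4 (0.25 log units; within the scatter)) or of amino (a 1.4-fold higher number from compound 1 to compound 4 (0.15 log units; within the scatter)) on the aromatic carbon, compound 4 also stays within the scatter of both compounds, even though those two lie beyond the scatter of each other. Nothing available explains why these steps are small.

All four compounds shown carry an aromatic ring on the carbonyl carbon, so a cyclohexyl group or a longer alkyl chain in its place remains an open case. Going by these compounds, a carboxylic acid on the aromatic ring also remains open.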